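Oxazole to thiazole swap across two amide cores

The source may report more compounds than this note shows. Statements on the series, on what has been measured and on what is new or still open speak of the compounds shown alone.

Compound 1 `Cc1c(Cc2ccc(-c3cocn3)cc2)cc(C(=O)N[C@H]2CCCC[C@@H]2O)c(=O)n1C` in an ADME assay on MDCKII-LE cells (Canis lupus familiaris) for permeability (a higher number here means that the compound crosses the layer faster, a lower number that the compound crosses the layer more slowly), gives 26 10^-6 cm/s. Compound 2 `Cc1c(Cc2ccc(-c3cscn3)cc2)cc(C(=O)N[C@H]2CCCC[C@@H]2O)c(=O)n1C` differs from it by 1,3-thiazol-4-yl in place of 1,3-oxazol-4-yl on an aromatic carbon; in this assay compound 2 gives 17 10^-6 cm/s, a step of a 1.5-fold lower number from compound 1 to compound 2 (0.18 log units; within the scatter).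

Compound 3 `Cc1cnc(C(=O)N[C@H]2CCOC[C@@H]2O)cc1Cc1ccc(-c2cocn2)cc1` carries a different core; how its core differs from that of compound 1 is not broken down here. In this assay compound 3 gives 32 10^-6 cm/s, a number that sits within the scatter of compound 1 and also within the scatter of compound 2, so no order among the three can be read.

Compound 4 `Cc1cnc(C(=O)N[C@H]2CCOC[C@@H]2O)cc1Cc1ccc(-c2cscn2)cc1` differs from compound 3 by 1,3-thiazol-4-yl in place of 1,3-oxazol-4-yl on an aromatic carbon. The place is described in the same words for both pairs, so this is the same change, seen in two pairs among the compounds here, one measured and one not.

For compound 4 in this assay a step of about a 1.5-fold lower number from compound 3 to compound 4 (0.16 log units; within the scatter) is expected. That expectation rests on compound 1 and compound 2, because a 1.5-fold lower number from compound 1 to compound 2 (0.18 log units; within the scatter) is the only measured instance of the change and falls within the scatter; nothing among these compounds indicates that the core of compound 3 would answer the change differently. Compound 4 is estimated at 22 10^-6 cm/s in this assay, with a range from 13 10^-6 cm/s to 36 10^-6 cm/s expected to cover most repeat measurements.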

Compound 4, apparent permeability: 22 10^-6 cm/s
Estimate against measurement, compound 4: no gap at the digits printed, within the range that was stated.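

In this assay the new pair reads a 1.5-fold lower number from compound 3 to compound 4 (0.16 log units; within the scatter) and stands close to the earlier pair, so 1,3-thiazol-4-yl in place of 1,3-oxazol-4-yl carries from one core to the other with no difference that can be told apart: the same change on two cores in this assay, a 1.5-fold lower number (0.18 log units; within the scatter) from compound 1 to compound 2 and a 1.5-fold lower number (0.16 log units; within the scatter) from compound 3 to compound 4, 1.1-fold (0.02 log units) apart, within the scatter of two such steps. For working purposes, the step measured on one of these two cores served as a fair guide to the step on the other, and on neither core did the swap move the number beyond the usual scatter. This does not show that the swap itself lowers the number, since two steps that each lie within the scatter do not establish a real effect even when they point the same way, and two cores say nothing firm about a third core or about a change large enough to read clearly.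

The compounds shown leave open how this assay would respond to a clearly different group at the same place, such as a carboxylic acid, an amine or a nitrile in place of the five-membered ring. They also leave open whether such a group would behave alike on both cores, which neither pair here can address.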